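The compounds below may be only part of what the source reports. "The series", "measured", "known", "first", "only" and "open" are said of these compounds alone.

Working notes on the series built on the shared core of compound 3 `N#Cc1ccc(Nc2nc(Oc3ccnc4ccccc34)nc(N3CCN(Cc4ccccc4)CC3)n2)cc1C(F)(F)F`. In a functional assay on DU-145 cells (Homo sapiens) for cytotoxicity, read by sulforhodamine B assay, with a stated time of 48 h (on this read-out higher numbers stand for weaker inhibition of growth and lower numbers for stronger inhibition of growth), compound 3 gives > 100000 nM, which is a limit of the assay and not a number. In this assay compound 1 `CCN1CCN(c2nc(Nc3ccc(C#N)c(C(F)(F)F)c3)nc(Oc3ccnc4ccccc34)n2)CC1` gives > 100000 nM, again only a limit. In this assay compound 2 `N#Cc1ccc(Nc2nc(Oc3ccnc4ccccc34)nc(N3CCN(C(c4ccccc4)c4ccc(Cl)cc4)CC3)n2)cc1C(F)(F)F` gives > 100000 nM, again only a limit. The step that the two limits leave unreadable from compound 1 to compound 3 is accordingly unreadable, and so is a step that the two limits leave unreadable from compound 2 to compound 3, as all three values sit at the limit of > 100000 nM in this assay, at which 3 of the 3 values shown sit. Compound 3 thus stands at the limit alongside every other measured value, with no number to place it against the others.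

Compound 4 `N#Cc1ccc(Nc2nc(Oc3ccnc4ccccc34)nc(N3CCN(C(c4ccccc4)c4ccccc4)CC3)n2)cc1C(F)(F)F` differs from compound 3 by phenyl in place of hydrogen on a saturated chain carbon bound to an amine nitrogen in a ring and an aromatic carbon. The two measured steps that bear on this change, a step that the two limits leave unreadable from compound 1 to compound 3 and a step that the two limits leave unreadable from compound 2 to compound 3, give no readable size, since every value in this assay rests at the limit of > 100000 nM in this assay, at which 3 of the 3 values shown sit. No step beyond the scatter can be read from them, and none is expected here. Compound 4 is expected to return the limit as well, an expected step of a number no higher from compound 3 to compound 4 (the limit leaves the size open). Compound 4 is estimated at 100000 nM, within 30000 nM to 300000 nM, with the limit itself the likeliest outcome.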

Compound 4, concentration for total growth inhibition: > 100000 nM
Compound 4: no number, only a limit; the forecaster's own chance of this, stated with the estimate: 85%; the middle value sits exactly at the limit.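

The steps from compound 3 to compound 4 and from compound 2 to compound 4 cannot be read, because each value is a limit and not a number: the limit of > 100000 nM in this assay, at which 4 of the 4 values shown sit.

The compounds shown leave open whether any group at this place changes growth inhibition in this assay.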